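Dropping One Chloro from a Dichlorobenzyl Imidazole-thione

A few compounds are considered here, and "the series" means these few. Any claim that something is new, unique, unknown or untested is made for them only; others in the source may bear on it.

Measured so far:
- compound 1, `Cc1ccccc1Cn1cc[nH]c1=S`, 339000 nM
- compound 2, `S=c1[nH]ccn1Cc1cc(Cl)ccc1Cl`, 97700 nM
- compound 3, `Oc1ccc(Cn2cc[nH]c2=S)cc1C(F)(F)F`, 120000 nM

All three were tested in an assay on isolated protein for inhibition of Dopamine beta-hydroxylase (Rattus norvegicus); a lower number here means a stronger inhibitor, a higher number a weaker inhibitor. Compound 2 gives the smallest number of the three, although compound 3 sits within the usual scatter of it and so cannot be told apart from it; compound 1 stands clearly apart with a higher number, meaning a weaker inhibitor. Compound 2 carries two chloro groups on its benzyl ring, while compound 1 carries a methyl group instead, and compound 3 a hydroxyl and a trifluoromethyl.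

Compound 4, `S=c1[nH]ccn1Cc1ccccc1Cl`, has not yet been measured. It differs from compound 2 in one place: hydrogen in place of chloro on an aromatic carbon. Among the measured compounds shown here, since no pair of measured compounds differs in just one place, there is no measured step to lean on. With the halogen gone, a modest move toward the weaker end seems likely, perhaps toward compound 1, which gives 339000 nM. The step from compound 2 to compound 4 is therefore expected to be a 2.0-fold higher number from compound 2 to compound 4 (0.31 log units; beyond the scatter), a rise in the number that is probably just beyond the scatter. Compound 4 is estimated at 200000 nM, expected to fall between 80000 nM and 500000 nM.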

Compound 4, half-maximal inhibitory concentration: 355000 nM
Beside the measured number, compound 4's estimate is 1.8-fold (0.25 log units) below it; the measured number falls inside the stated range.
By their numbers in this assay, from the lowest: compounds 2 and 3 (each within the scatter of the next); then compounds 1 and 4 (each within the scatter of the next).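

Among the compounds shown here, the chloro group that sits para to a chloro group and meta to a group of 7 heavy atoms matters in this assay: replacing it with hydrogen gives a 3.6-fold higher number from compound 2 to compound 4 (0.56 log units; beyond the scatter) and so a weaker inhibitor, the first measured one-place change at this position. Exchanging methyl for chloro on the ring gives a 1.0-fold higher number from compound 1 to compound 4 (0.02 log units; within the scatter) and leaves compound 1 and compound 4 indistinguishable, so that exchange shows no measurable effect here. No measurement here explains why losing the chloro group weakens inhibition.

Going by these compounds, whether a bromo, a methoxy or an amine could replace the lost chloro group and keep the inhibition of compound 2 remains open. So does the contribution of the chloro group kept in compound 4, which only a comparison with an unsubstituted benzyl ring could show.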